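A few compounds are considered here, and "the series" means these few. Any claim that something is new, unique, unknown or untested is made for them only; others in the source may bear on it.

Measured so far:
Compound 1 `COc1ccc(/C=C/c2cc(/C=C/c3ccc(OC)c(OC)c3)nc(OCCCCCCBr)n2)cc1OC`: in a functional assay on A549 cells (Homo sapiens) for cytotoxicity, read by fluorescence and resazurin assay, with a stated time of 48 h (a lower number here means a stronger inhibitor, a higher number a weaker inhibitor), compound 1 gives > 20000 nM, a limit of the assay and not a number.
Compound 2 `COc1cc(/C=C/c2cc(/C=C/c3cc(OC)c(OC)c(OC)c3)nc(OCCCCCBr)n2)cc(OC)c1OC`: in this assay compound 2 gives > 20000 nM, again a limit of the assay.
Compound 3 `BrCCCCCCOc1nc(/C=C/c2ccccc2)cc(/C=C/c2ccccc2)n1`: in this assay compound 3 gives > 20000 nM, also a limit of the assay.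

Compound 2 therefore stands at the limit, with nothing to separate it from the other two: all three values sit at the limit of > 20000 nM in this assay, at which 3 of the 3 values shown sit. Among the compounds with values here, no pair of measured compounds differs in one place, so no measured step can be sized.

Compound 4 `COc1cc(/C=C/c2cc(/C=C/c3cc(OC)c(OC)c(OC)c3)nc(OCCCCCCBr)n2)cc(OC)c1OC` differs from compound 2 by bromomethyl in place of bromo on a saturated chain carbon, five bonds along the chain from an oxygen on an aromatic ring. The expectation for compound 4 rests on compound 2 alone, whose value is a limit. The step from compound 2 to compound 4 in this assay is expected to be none beyond the scatter, a step that the limit leaves unreadable from compound 2 to compound 4. Compound 4 is estimated at 30000 nM, between 15000 nM and 80000 nM, and is expected to be reported most likely as a limit only.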

Compound 4, half-maximal inhibitory concentration: > 20000 nM
Compound 4 was reported as a limit; the forecaster's own chance of this, stated with the estimate: 85%; the middle value is on the limit's open side.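

No step can be read from compound 2 to compound 4 in this assay, since both are reported only as limits: the limit of > 20000 nM in this assay, at which 4 of the 4 values shown sit.

The compounds shown leave open how far any of the four lies past that limit, and whether bromomethyl in place of bromo changes the read-out at all.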